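This account rests on a few compounds, and the source may have more. Where it says the series, first, only, none or still open, it means among the compounds named here.

Measured so far:
- compound 1, `CCOC(=O)c1c(CN(CC)Cc2ccccc2)nc2ccccc2c1-c1ccccc1`: 700 nM
- compound 2, `CCOC(=O)c1c(CN2CCc3ccccc3C2)nc2ccccc2c1-c1ccccc1`: 1190 nM

Among the compounds with values here, in an assay on brain with Translocator protein (Rattus norvegicus) as the target (a higher number here means a weaker inhibitor, a lower number a stronger inhibitor), compound 1 gives the lowest of the two numbers, and the only neighbour is compound 2, where the change is a 1.7-fold higher number from compound 1 to compound 2 (0.23 log units; within the scatter); this step lies within the scatter, so the two values cannot be told apart.

The unmeasured compound 3, `CCCN(CCC)C(=O)c1c(CN(CC)Cc2ccccc2)nc2ccccc2c1-c1ccccc1`, differs from compound 1 in one place: dipropylamino in place of ethoxy on a carbonyl carbon. Within the data shown here, the single measured step, from compound 1 to compound 2, concerns a different part of the molecule, the group on the saturated chain carbon, and leaves the ethoxycarbonyl untouched. Among the measured compounds shown here, no measured step therefore bears on the change from ethoxy to dipropylamino on the carbonyl carbon, and the expectation for compound 3 rests on compound 1 alone, with a wide range around it.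

For compound 3 in this assay the estimate is 250 nM, with a range from 40 nM to 1500 nM. This estimate means an expected step of a 2.8-fold lower number from compound 1 to compound 3 (0.45 log units; beyond the scatter), which may or may not exceed the scatter.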

Compound 3, half-maximal inhibitory concentration: 456 nM
Estimate against measurement, compound 3: 1.8-fold (0.26 log units) below; low and high end bracket the measured number.
By their numbers in this assay, from the lowest: compounds 3, 1 and 2 (each within the scatter of the next, the first and the last beyond it).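

Until this result, the ethoxycarbonyl had been the same in every compound shown, so nothing showed how this assay responds to a change on this carbonyl carbon. Putting dipropylamino in place of ethoxy turns the ethoxycarbonyl into a dipropylcarbamoyl and brings in 7 heavy atoms where 3 stood, yet the result is a 1.5-fold lower number from compound 1 to compound 3 (0.19 log units; within the scatter), so the two compounds cannot be told apart here and this position accepts either group with no measurable difference. No available measurement offers an explanation for this result.

The compounds shown leave open whether the same holds for other groups on this carbonyl carbon, such as dimethylamino, piperidine joined through its nitrogen, or the free carboxylic acid. They also leave open whether dipropylamino gives a comparable number when the 1,2,3,4-tetrahydroisoquinolin-2-yl group of compound 2 takes the place of benzyl(ethyl)amino on the saturated chain carbon, since only one change at a time has been examined in the compounds shown.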